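Thiophen-3-yl for furan-2-yl on the enone carbonyl

This account rests on a few compounds, and the source may have more. Where it says the series, first, only, none or still open, it means among the compounds named here.

The series shares one core and varies the group hung on the carbonyl of the enone, or in the case of compound 1 `COc1ccc(-c2cc3ccccc3nc2C=O)cc1` carries only a formyl there. In a functional assay on H184B5F5/M10 cells (Homo sapiens) for antiproliferative activity, read by XTT assay, with a stated time of 72 h (a lower number here means a stronger inhibitor, a higher number a weaker inhibitor), compound 1 gives > 10000 nM, which is a limit of the assay rather than a number. Compound 2 `COc1ccc(-c2cc3ccccc3nc2/C=C/C(=O)c2ccc(F)cc2)cc1` carries a 4-fluorophenyl on the carbonyl. In this assay compound 2 likewise gives > 10000 nM, again a limit. Within the data shown here, compound 3 `COc1ccc(-c2cc3ccccc3nc2/C=C/C(=O)c2ccco2)cc1`, with a furan-2-yl on the carbonyl, is the only member with a number in this assay, where compound 3 gives 6240 nM. The two measured steps both end at compound 3: an at least 1.6-fold lower number from compound 1 to compound 3 (0.20 log units; that floor lies within the scatter) and an at least 1.6-fold lower number from compound 2 to compound 3 (0.20 log units; that floor lies within the scatter), each a floor that sits within the scatter, since both start at the limit of > 10000 nM in this assay, at which 2 of the 3 values shown sit.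

Compound 4 `COc1ccc(-c2cc3ccccc3nc2/C=C/C(=O)c2ccsc2)cc1` differs from compound 3 by thiophen-3-yl in place of furan-2-yl on a carbonyl carbon. Among the measured compounds shown here, the closest precedent is the swap on the same carbonyl from compound 2 to compound 3, whose size is bounded only from one side. Thiophen-3-yl and furan-2-yl match in atom count and acceptor count, so a step within the scatter is expected for compound 4, in this assay amounting to a 1.0-fold lower number from compound 3 to compound 4 (0.02 log units; within the scatter). Compound 4 is therefore estimated at 6000 nM, with a range from 2000 nM to 15000 nM.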

Compound 4, half-maximal inhibitory concentration: 6390 nM
For compound 4 the middle estimate is 1.1-fold (0.03 log units) below the measured one; the range from low to high includes it.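

In this assay, replacing furan-2-yl with thiophen-3-yl on the carbonyl carbon gives a 1.0-fold higher number from compound 3 to compound 4 (0.01 log units; within the scatter), so exchanging the oxygen of the five-membered aromatic ring for sulfur, together with the change from a 2-yl to a 3-yl ring, leaves the number within the scatter. Among these compounds, compound 3 is therefore no longer the only member with a number, and both compounds with a five-membered aromatic ring on this carbonyl now read as numbers, although two compounds offer only a narrow basis for any pattern. Set against the other two compounds, the result gives an at least 1.5-fold lower number from compound 2 to compound 4 (0.19 log units; that floor lies within the scatter) and an at least 1.5-fold lower number from compound 1 to compound 4 (0.19 log units; that floor lies within the scatter), and neither floor separates compound 4 from its partner beyond the scatter because both steps start at a limit: the limit of > 10000 nM in this assay, at which 2 of the 4 values shown sit.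

The compounds shown leave open how far compound 2 and compound 1 truly lie from compound 3 and compound 4, since their limits bound those steps from one side only. They also leave open whether a thiophen-2-yl, a pyridin-3-yl or an unsubstituted phenyl on the same carbonyl carbon would stay within the scatter of these two values.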